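From cyclohexyl to cyclooctyl on the amide nitrogen

The source may report more compounds than this note shows. Statements on the series, on what has been measured and on what is new or still open speak of the compounds shown alone.

In a functional assay on A549 cells (Homo sapiens) for antiproliferative activity, read by WST assay, with a stated time of 72 h (a lower number here means a stronger inhibitor, a higher number a weaker inhibitor), compound 3 `O=C(CCCCCCn1cc(C(=O)NC2CCCCC2)c2ccccc21)NO` reports only a limit, > 100000 nM. Compound 1 `O=C(CCCCCCn1cc(C(=O)NCc2ccc(Cl)cc2)c2ccccc21)NO` also reports only a limit, > 100000 nM. Going by the values given here, compound 2 `O=C(CCCCCCn1cc(C(=O)Nc2ccc(Cl)cc2Cl)c2ccccc21)NO` gives the only actual number, 47000 nM. The other two compounds therefore stand at the limit of > 100000 nM in this assay, at which 2 of the 3 values shown sit. Changing the group on the amide-type nitrogen gave an at least 2.1-fold lower number from compound 1 to compound 2 (0.32 log units; beyond the scatter), an at least 2.1-fold higher number from compound 2 to compound 3 (0.32 log units; beyond the scatter) and a step that the two limits leave unreadable from compound 1 to compound 3.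

Compound 4 `O=C(CCCCCCn1cc(C(=O)NC2CCCCCCC2)c2ccccc21)NO` changes the same place, and the difference is cyclooctyl in place of cyclohexyl on an amide-type nitrogen. Among the compounds with values here, no measured step covers a change in the size of a non-aromatic ring of carbon only, so the comparison is indirect. Within the data shown here, the expectation leans on compound 2 at 47000 nM, the one compound with an actual number. At most a modest move towards a lower number is expected, and a result at the limit would be no surprise. The estimate means an at least 1.2-fold lower number from compound 3 to compound 4 (0.09 log units; that floor lies within the scatter). For compound 4 the estimated value is 80000 nM, with an expected range from 30000 nM to 150000 nM.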

Compound 4, half-maximal inhibitory concentration: > 100000 nM
Compound 4 was reported as a limit; the forecaster's own chance of this, stated with the estimate: 60%; middle value at least 1.2-fold (0.09 log units) away from the limit.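

Compound 4 is also reported only as a limit in this assay, so taking the ring of carbon only from six-membered to eight-membered on the amide-type nitrogen gave no readable number, and the steps from compound 3 and from compound 1 to compound 4 cannot be read. Cyclooctyl now joins cyclohexyl and 4-chlorobenzyl at the ceiling of this assay: the limit of > 100000 nM in this assay, at which 3 of the 4 values shown sit. Going by these compounds alone, with cyclooctyl in place of 2,4-dichlorophenyl there is an at least 2.1-fold higher number from compound 2 to compound 4 (0.32 log units; beyond the scatter), so compound 2 keeps its place as the only compound with an actual number.

On these data alone, how far compound 1, compound 3 and compound 4 lie from one another remains unknown. As far as these compounds go, it also remains open whether another group on this nitrogen, such as plain phenyl or 4-chlorophenyl, would give a readable number.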